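The source may hold more compounds than are shown below. What is called first, only, known or untested is meant among the compounds shown, and "the series" means these compounds.

Compound 1: `CC(C)=CCC/C(C)=C/CC/C(C)=C/CC[C@]1(C)CCc2cc(OC(=O)NC(=O)Oc3ccccc3)cc(C)c2O1`; in a functional assay on MDA-MB-231 cells (Homo sapiens) for antiproliferative activity, read by MTT assay, with a stated time of 96 h (on this read-out lower numbers stand for stronger inhibition and higher numbers for weaker inhibition), compound 1 is reported as "not determined" (no result reported).
Compound 2: `CC(C)=CCC/C(C)=C/CC/C(C)=C/CC[C@]1(C)CCc2c(C)c(OC(=O)NCc3ccccc3)c(C)c(C)c2O1`; compound 2 gives 7200 nM in this assay.
Compound 3: `CC(C)=CCC/C(C)=C/CC/C(C)=C/CC[C@]1(C)CCc2cc(OC(=O)NCc3ccccc3)c(C)c(C)c2O1`; compound 3 is reported as a limit, > 10000 nM, in this assay.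

Compound 2 thus holds the only single number shown in this assay; compound 3 sits at the limit of > 10000 nM in this assay, at which 1 of the 3 values shown sits, and compound 1 has no result. Within the data shown here, the one measured step, an at least 1.3-fold higher number from compound 2 to compound 3 (0.14 log units; that floor lies within the scatter), concerns hydrogen in place of methyl on an aromatic carbon and does not touch the carbamate substituent. Compound 4 `CC(C)=CCC/C(C)=C/CC/C(C)=C/CC[C@]1(C)CCc2c(C)c(OC(=O)NS(=O)(=O)c3ccccc3)c(C)c(C)c2O1` differs from compound 2 by phenylsulfonyl in place of benzyl on an amide-type nitrogen. Among the measured compounds shown here, no measured step bears on this change, so no step beyond the scatter is expected in either direction. Compound 4 is therefore estimated at 8000 nM, range 3000 nM to 20000 nM, the expected step being a 1.1-fold higher number from compound 2 to compound 4 (0.05 log units; within the scatter) in this assay.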

Compound 4, half-maximal inhibitory concentration: > 10000 nM
Compound 4: only a limit was reported; the forecaster's own chance of this, stated with the estimate: 40%; middle value at least 1.2-fold (0.09 log units) from the limit.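

In this assay compound 4 gives > 10000 nM, which is a limit and not a number. Phenylsulfonyl in place of benzyl on the amide-type nitrogen gives an at least 1.3-fold higher number from compound 2 to compound 4 (0.14 log units; that floor lies within the scatter), so this change at the carbamate substituent shows no step beyond the scatter, and its true size cannot be read. Compound 4 adds to the entries without a single number: the limit of > 10000 nM in this assay, at which 2 of the 4 values shown sit.

Going by these compounds, whether a longer chain ending in an amine or a carboxylic acid on this nitrogen would shift the value of compound 2 stays open. Among these compounds, the shared core offers only one measured step, so how substituents there combine with this change also stays open.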